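From Nitro to Methylsulfanyl: Expecting Compound 4

The compounds below may be only part of what the source reports. "The series", "measured", "known", "first", "only" and "open" are said of these compounds alone.

Compound 1 `COc1cc(C(=O)/C=C/c2cn(C)c3ccccc23)cc(SC)c1OC`: 150 nM
Compound 2 `COc1ccc2c(/C=C/C(=O)c3cc(OC)c(OC)c([N+](=O)[O-])c3)cn(C)c2c1`: 562 nM
Compound 3 `COc1ccc2c(/C=C/C(=O)c3cc(OC)c(OC)c([N+](=O)[O-])c3)c[nH]c2c1`: 289 nM

In a functional assay on MHCC97H cells (Homo sapiens) for antiproliferative activity, read by MTT assay, with a stated time of 48 h (on this read-out lower numbers stand for stronger inhibition and higher numbers for weaker inhibition), compound 2 gives the highest number of the three; compound 3 sits within the scatter of it, a 1.9-fold lower number from compound 2 to compound 3 (0.29 log units; within the scatter), while compound 1 lies further off, beyond the scatter. Compound 4 `COc1ccc2c(/C=C/C(=O)c3cc(OC)c(OC)c(SC)c3)cn(C)c2c1` is made from compound 2 by one change, (methylsulfanyl in place of nitro on an aromatic carbon), placed ortho to a methoxy group and meta to a methoxy group and to a large group. Among the measured compounds shown here, no measured step shows this exact swap. Compound 1, which also carries a methylsulfanyl group beside methoxy groups, gives the lowest number, so a modest move toward lower numbers is expected, a 2.2-fold lower number from compound 2 to compound 4 (0.35 log units; beyond the scatter). Compound 4 is therefore estimated at 250 nM, within 100 nM to 600 nM.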

Compound 4, half-maximal inhibitory concentration: 122 nM
Estimate against measurement, compound 4: 2.0-fold (0.31 log units) above; measured number inside the range.
By their numbers in this assay, from the lowest: compounds 4, 1, 3 and 2 (each within the scatter of the next, the first and the last beyond it).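

In this assay methylsulfanyl in place of nitro, on this aromatic carbon ortho to a methoxy group, gives a 4.6-fold lower number from compound 2 to compound 4 (0.66 log units; beyond the scatter) as the first step shown at this position. With methylsulfanyl present, methoxy in place of hydrogen on an aromatic carbon gives only a 1.2-fold lower number from compound 1 to compound 4 (0.09 log units; within the scatter) and so separates these two compounds by no more than repeated measurements would.

On these data alone, whether an amine, a carboxylic acid or a longer sulfur chain at this position would hold the number as low remains open. The reason for the step also stays open, as no measurement shown bears on it.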